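Cytotoxicity notes: nitro added to compound 3

The source may report more compounds than this note shows. Statements on the series, on what has been measured and on what is new or still open speak of the compounds shown alone.

Among the compounds with values here, in an ADME assay on L6 cells (Rattus norvegicus) for cytotoxicity, read by resazurin assay, with a stated time of 72 h (on this read-out higher numbers stand for weaker inhibition and lower numbers for stronger inhibition), three compounds have numbers so far. Compound 1 (`CC(=O)OC[C@H]1O[C@@H](N2C(=O)/C(=C3/C(=O)Nc4ccc(I)cc43)c3ccccc32)[C@H](OC(C)=O)[C@@H](OC(C)=O)[C@@H]1OC(C)=O`) gives 11300 nM, compound 2 (`CC(=O)OC[C@H]1O[C@@H](N2C(=O)/C(=C3/C(=O)Nc4ccc(Br)cc43)c3ccccc32)[C@H](OC(C)=O)[C@@H](OC(C)=O)[C@@H]1OC(C)=O`) gives 7700 nM and compound 3 (`CCCC(=O)c1ccc2c(c1)/C(=C1\C(=O)N([C@@H]3O[C@H](COC(C)=O)[C@@H](OC(C)=O)[C@H](OC(C)=O)[C@H]3OC(C)=O)c3ccccc31)C(=O)N2`) gives 31700 nM. Compound 3 therefore holds the highest of the three numbers, and its gaps to both others lie beyond the scatter.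

Compound 4 (`CCCC(=O)c1ccc2c(c1)/C(=C1\C(=O)N([C@@H]3O[C@H](COC(C)=O)[C@@H](OC(C)=O)[C@H](OC(C)=O)[C@H]3OC(C)=O)c3cc([N+](=O)[O-])ccc31)C(=O)N2`) differs from compound 3 by nitro in place of hydrogen on an aromatic carbon.

The measured steps all exchange one aromatic substituent for another. The halogen swap, a 1.5-fold lower number from compound 1 to compound 2 (0.17 log units; within the scatter), stays within the scatter, whereas a 2.8-fold higher number from compound 1 to compound 3 (0.45 log units; beyond the scatter) and a 4.1-fold higher number from compound 2 to compound 3 (0.61 log units; beyond the scatter) are modest. None of these steps introduces nitro or alters the carbon that changes here, so they suggest a plausible size in this assay but no firm direction. Within the data shown here, compound 3 sits at the top of a set of only three numbers, which gives a slight lean towards a lower number and nothing more.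

The expected change is small, and the estimate is a 1.6-fold lower number from compound 3 to compound 4 (0.20 log units; within the scatter); a step in the opposite direction cannot be excluded. For compound 4 the estimated value is 20000 nM, with an expected range from 7000 nM to 50000 nM.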

Compound 4, half-maximal inhibitory concentration: 10700 nM
The estimate for compound 4 lay 1.9-fold (0.27 log units) above the measured number; the measured number falls inside the stated range.
By their numbers in this assay, from the lowest: compounds 2, 4 and 1 (each within the scatter of the next); then compound 3.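

In this assay, within the data shown here, the earlier steps only exchanged one substituent for another on a single aromatic carbon, so this is the first look at a second carbon, the one meta to a fused ring and para to a fused ring, and substitution there is not silent: nitro in place of hydrogen gives a 3.0-fold lower number from compound 3 to compound 4 (0.47 log units; beyond the scatter), with the propylcarbonyl group kept in place. The step is modest but beyond the scatter, and it shows that the position can shift the read-out towards stronger inhibition in a compound that otherwise holds the highest number of the set, although a single pair gives one direction at one carbon and no trend. No measured data on any property of the compounds bear on this step, so its origin remains unexplained.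

From the compounds shown here alone, whether an amine or a nitrile on this same carbon would move the number in the same direction and by a similar size remains open. Also open, going by these compounds, is whether nitro gives a comparable step when bromo or iodo replaces propylcarbonyl, so additivity between the two positions cannot be judged from these compounds.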